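The source may hold more compounds than are shown below. What is called first, only, known or untested is meant among the compounds shown, and "the series" means these compounds.

The study measures growth inhibition in a functional assay on U-373MG ATCC cells (Homo sapiens) for inhibition, read by MTT assay, with a stated time of 72 h; a higher number here means a weaker inhibitor, a lower number a stronger inhibitor. Of the compounds shown here, three have numbers so far. Compound 1 `CC(C)NC(=O)NC1CC(C)(C)Oc2ccc(Cl)cc21` gives 62000 nM in this assay. Compound 2 `O=[N+]([O-])c1cccc(NC(=S)NCc2cccc(Cl)c2)c1` gives 32000 nM in this assay. Compound 3 `CC1(C)CC(NC(=O)NCc2ccccc2)c2cc(F)ccc2O1` gives 11000 nM in this assay. Compound 2 thus holds the second highest of the three numbers: its nearest neighbour is compound 1, whose value lies within the usual scatter of it, while compound 3 sits furthest away, with a lower number that falls beyond the scatter. All three compounds are weak inhibitors in this assay.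

The next compound, compound 4 `COc1ccc(Cl)cc1CNC(=S)Nc1cccc([N+](=O)[O-])c1`, differs from compound 2 in one place: methoxy in place of hydrogen on an aromatic carbon. The methoxy sits on an aromatic carbon of a six-membered aromatic ring of carbon only, ortho to a large group and para to a chloro group. Going by the values given here, no measured pair in this set shares this change, so there is no precedent to lean on. Compound 4 is expected to stay close to compound 2 in this assay, and the step of a 1.3-fold lower number from compound 2 to compound 4 (0.11 log units; within the scatter) is expected to lie within the scatter. The estimate for compound 4 is 25000 nM, with a range from 8000 nM to 80000 nM.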

Compound 4, half-maximal inhibitory concentration: 32000 nM
Estimate against measurement, compound 4: 1.3-fold (0.11 log units) below; measured number inside the range.
By their numbers in this assay, from the lowest: compound 3; then compounds 2, 4 and 1 (each within the scatter of the next).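

In this assay, going by these compounds alone, the step of no change at the digits printed from compound 2 to compound 4 (within the scatter) is the only one so far between compounds that differ in one place, and it gives the set its first direct reading of a single change. It shows that methoxy in place of hydrogen on this aromatic carbon, ortho to a large group and para to a chloro group, produces no shift in the number, and both compounds remain weak inhibitors. No measurement available here bears on why the number stays the same.

The compounds shown leave open whether another group at this position, such as an amine, a carboxylic acid or a longer alkoxy chain, would also leave the number unchanged. They also leave open whether replacing the chloro group or the nitro group of compound 2 would move the number beyond the scatter.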